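The source may hold more compounds than are shown below. What is called first, only, known or untested is meant among the compounds shown, and "the series" means these compounds.

Compound 1 `O=C(O)[C@H]1NC[C@@H](O)[C@H](O)[C@H]1O`, compound 2 `O=C(O)[C@H]1NC[C@H](O)[C@@H](O)[C@@H]1O` and compound 3 `O=C(O)[C@@H]1NCC=C[C@H]1O` share one piece of data. In an assay for inhibition of alpha-N-acetylgalactosaminidase (Gallus gallus), tested at 1000 uM (a higher number here means more inhibition at the concentration tested (going by the name of the read-out), a lower number less inhibition), compound 1 gives 4.2%, compound 2 gives 0.2% and compound 3 gives 3.2%, so all three lie within the scatter of one another and compound 2 cannot be set apart from either. Compound 4 `O=C(O)[C@H]1NC[C@@H](O)[C@H](O)[C@@H]1O` differs from compound 2 in this way: the two compounds have the same atoms and bonds and differ only in configuration as drawn: 2 of 4 stereo elements differ; a stereocentre at a saturated ring carbon is drawn S in compound 2 and R in compound 4; a stereocentre at a saturated ring carbon is drawn R in compound 2 and S in compound 4. Among the compounds with values here, the one measured step that bears on this is a number 4 percentage points lower from compound 1 to compound 2 (within the scatter), a comparison that counts because of the fact that compounds 1 and 2 differ only in the configuration as drawn. A change of configuration alone thus gave nothing beyond the scatter there, and the expected step of a number 2.8 percentage points higher from compound 2 to compound 4 (within the scatter) is likewise none beyond the scatter. For compound 4 the expected inhibition is therefore 3%, between -5% and 12%.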

Compound 4, a percentage reported as inhibition, at one concentration (the size of the read-out at that concentration, not a potency): 11%
Estimate against measurement, compound 4: 8 percentage points below; measured number inside the range.
By their numbers in this assay, from the lowest: compounds 2, 3, 1 and 4 (each within the scatter of the next, the first and the last beyond it).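

In this assay a change of configuration alone now gives a modest step beyond the scatter, a number 10.8 percentage points higher from compound 2 to compound 4 (beyond the scatter), which the earlier pair had not shown; nothing enters or leaves: the fact that compounds 2 and 4 differ only in the configuration as drawn. The change at a single saturated ring carbon, a number 6.8 percentage points higher from compound 1 to compound 4 (within the scatter), stays within the scatter: the fact that compounds 1 and 4 differ only in the configuration as drawn. The compounds shown do not tell which of the two stereocentres that separate compound 2 from compound 4 carries the step. They also leave open whether an amide in place of the carboxylic acid would alter the inhibition.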